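This account rests on a few compounds, and the source may have more. Where it says the series, first, only, none or still open, it means among the compounds named here.

In an ADME assay on MT4 cells (Homo sapiens) for cytotoxicity, read by MTT assay, with a stated time of 4 days (a higher number here means that more compound is tolerated, a lower number that less compound is tolerated), compound 1 `Nc1ccc2oc(-c3ccccc3F)cc(=O)c2c1` gives 283000 nM, compound 2 `Nc1ccc2oc(-c3ccccc3F)c(O)c(=O)c2c1` gives 44500 nM and compound 3 `COc1c(-c2ccccc2)oc2ccc(N)cc2c1=O` gives 126000 nM, which places compound 3 second of the three, between the other two. Compound 4 `COc1c(-c2ccccc2F)oc2ccc(N)cc2c1=O` differs from compound 3 by fluoro in place of hydrogen on an aromatic carbon, turning phenyl into 2-fluorophenyl. Going by the values given here, no measured pair isolates this change. Among the compounds with values here, the only measured step, a 6.4-fold lower number from compound 1 to compound 2 (0.80 log units; beyond the scatter), is a different change, made between two compounds that both carry 2-fluorophenyl, and their values fall on either side of compound 3. No step beyond the scatter is therefore expected in this assay, and the estimate is a 1.1-fold lower number from compound 3 to compound 4 (0.02 log units; within the scatter). For compound 4 the expected value is 120000 nM, with an estimated range of 55000 nM to 250000 nM.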

Compound 4, half-maximal cytotoxic concentration: 234000 nM
The estimate for compound 4 lay 2.0-fold (0.29 log units) below the measured number; the measured number falls inside the stated range.
By their numbers in this assay, from the lowest: compound 2; then compounds 3, 4 and 1 (each within the scatter of the next, the first and the last beyond it).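

In this assay, fluoro in place of hydrogen on the phenyl gives a 1.9-fold higher number from compound 3 to compound 4 (0.27 log units; within the scatter) and so, in this one isolated case, makes no difference that stands clear of the scatter. With 2-fluorophenyl present, methyl in place of the hydroxy hydrogen gives a 5.3-fold higher number from compound 2 to compound 4 (0.72 log units; beyond the scatter) and methoxy in place of the aromatic hydrogen gives a 1.2-fold lower number from compound 1 to compound 4 (0.08 log units; within the scatter) and together these tie the low number of compound 2 to its free hydroxy rather than to any group at that carbon. From the compounds shown here alone, whether chloro in place of fluoro or an amine in place of methoxy would match these numbers remains open. No measurement here explains the numbers.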